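Acetyl for Methyl on the Sulfonamide Aryl Ring

A few compounds are considered here, and "the series" means these few. Any claim that something is new, unique, unknown or untested is made for them only; others in the source may bear on it.

Compound 1, `N#CCCN(Cc1cccs1)S(=O)(=O)c1ccccc1F`, in an ADME assay on MDCK cells (Canis lupus familiaris) for cytotoxicity, read by MTT assay, with a stated time of 24 h; on this read-out higher numbers stand for lower toxicity in this test and lower numbers for higher toxicity in this test: > 205000 nM, a limit of this assay and not a number.
Compound 2, `Cc1ccc(S(=O)(=O)N(CCC#N)Cc2cccs2)cc1`, in this assay: 127000 nM.

Compound 2 gives the only plain number shown; the other value is a limit. Compound 1 sits at the limit of > 205000 nM in this assay, at which 1 of the 2 values shown sits. The step of an at least 1.6-fold lower number from compound 1 to compound 2 (0.20 log units; that floor lies within the scatter) therefore has only a floor, and that floor lies within the scatter.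

Compound 3, `CC(=O)c1ccc(S(=O)(=O)N(CCC#N)Cc2cccs2)cc1`, differs from compound 2 by acetyl in place of methyl on an aromatic carbon. No measured step touches this position, and the one step shown, an exchange of the whole ring on the sulfonyl sulfur, stayed within the scatter. No basis is seen for a shift in either direction, so the step of no change at the digits printed from compound 2 to compound 3 (within the scatter) is expected to stay within the scatter. Compound 3 is estimated at 127000 nM, with a range from 55000 nM to 250000 nM.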

Compound 3, half-maximal cytotoxic concentration: > 191000 nM
Compound 3: a limit, no number; the forecaster's own chance of this, stated with the estimate: 35%; at least 1.5-fold (0.17 log units) between middle value and limit.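

Acetyl in place of methyl, on an aromatic carbon para to a large group, is the only step shown at this position, and in this assay it gives an at least 1.5-fold higher number from compound 2 to compound 3 (0.17 log units; that floor lies within the scatter). Compound 3 gives a limit and not a number, and the step has only a floor because of that limit: the limit of > 191000 nM in this assay, at which 1 of the 3 values shown sits. The position thus takes acetyl, which brings one hydrogen-bond acceptor and a double bond outside the aromatic rings, with no lower number in this test.

Going by these compounds, what the true value of compound 3 is, and whether the step from methyl to acetyl goes beyond the scatter, stays open. The compounds shown also leave open how an amine, a carboxylic acid or a longer acyl chain at this position would read in this assay.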